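Series notes: bromo entry on the thiophen-2-yl group

This account rests on a few compounds, and the source may have more. Where it says the series, first, only, none or still open, it means among the compounds named here.

Measured so far:
compound 1 `CC(=O)Oc1cccc2cc(-c3cccs3)c(=O)oc12` gives 2580 nM in an assay on CHO cells for displacement of a labelled ligand from transmembrane domain-containing protein TMIGD3 (Homo sapiens); on this read-out higher numbers stand for weaker inhibition and lower numbers for stronger inhibition
compound 2 `O=c1oc2c(O)cccc2cc1-c1cccs1` gives 1430 nM in this assay
compound 3 `O=c1oc2c(O)c(O)ccc2cc1-c1cccs1` gives 4830 nM in this assay

Compound 3 sits at the high end of the measured numbers in this assay; compound 1 lies within the scatter of it, whereas the step of a 3.4-fold higher number from compound 2 to compound 3 (0.53 log units; beyond the scatter) stands beyond the scatter. The other measured step, a 1.8-fold lower number from compound 1 to compound 2 (0.26 log units; within the scatter), lies within the scatter.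

Compound 4 `O=c1oc2c(O)c(O)ccc2cc1-c1cc(Br)cs1` differs from compound 3 by bromo in place of hydrogen on an aromatic carbon. For the measured compounds named here, both measured steps concern the oxygen substituents on the six-membered aromatic ring of the shared core; neither touches the thiophen-2-yl group, so no measured step bears directly on this change. The change itself is small, one heavy atom with no donors or acceptors. In this assay the expectation for compound 4 is therefore a step of a 1.0-fold lower number from compound 3 to compound 4 (0.00 log units; within the scatter), that is, nothing beyond the scatter. Compound 4 is estimated at 4800 nM, with a range from 1500 nM to 15000 nM, the width reflecting the absence of any measured precedent for substitution on the five-membered ring.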

Compound 4, inhibition constant: 3400 nM
The estimate for compound 4 lay 1.4-fold (0.15 log units) above the measured number; the measured number falls inside the stated range.
By their numbers in this assay, from the lowest: compounds 2, 1, 4 and 3 (each within the scatter of the next, the first and the last beyond it).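

Substitution on the thiophen-2-yl group now has a first reading in this assay: the change to 4-bromothiophen-2-yl gives a 1.4-fold lower number from compound 3 to compound 4 (0.15 log units; within the scatter) and so stays within the scatter. The earlier steps shown here covered only the oxygen substituents on the six-membered aromatic ring, whereas this one shows that a bromo at this carbon of the five-membered ring, two ring bonds from the ring sulfur, leaves the number of the compound 3 scaffold unmoved beyond the scatter. No measurement at hand offers an explanation for this outcome.

Still open, on these data alone, is how this position responds to groups other than bromo, such as a methoxy group, an amine or a carboxylic acid. Also open, as far as these compounds go, is whether bromo gives the same reading on the core of compound 2, which carries a single hydroxy group.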